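The compounds below may be only part of what the source reports. "The series", "measured", "known", "first", "only" and "open" are said of these compounds alone.

Measured so far:
Compound 1, `COc1c(C(=O)CCC2CCN(CC3CCCCC3)CC2)cc(Cl)c2[nH]ccc12`: 100%
Compound 2, `O=C(CCC1CCN(Cc2ccccc2)CC1)c1ccc2[nH]ccc2c1`: 90%

Both were tested in an assay for displacement of a labelled ligand from 5-hydroxytryptamine receptor 4 (Homo sapiens), with a stated time of 60 min, tested at 1 uM; on this read-out lower numbers stand for less inhibition and higher numbers for more inhibition at the one concentration tested (going by the name of the read-out). Compound 1 gives 100%, and compound 2 gives 90%. For the measured compounds named here, compound 2 has the lower of the two numbers, yet its only neighbour, compound 1, lies within the scatter of it, so the two cannot be told apart on this read-out. Going by the values given here, no pair of measured compounds differs in one place only, so no single step has been computed from the data.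

Compound 3 `O=C(CCC1CCN(CC2CCCC2)CC1)c1ccc2[nH]ccc2c1` has not yet been measured. It differs from compound 2 by cyclopentyl in place of phenyl on a saturated chain carbon bound to an amine nitrogen in a ring. Compound 1 differs from compound 2 in several other parts of its structure as well, so its value says nothing about this change on its own. With both measured numbers high and close together, the step of a number 2 percentage points lower from compound 2 to compound 3 (within the scatter) is expected to stay within the scatter, in no clear direction. Compound 3 is therefore expected to give about 88%, with a range from 70% to 100%.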

Compound 3, a percentage reported as inhibition, at one concentration (the size of the read-out at that concentration, not a potency): 100%
Estimate against measurement, compound 3: 12 percentage points below; measured number inside the range.
By their numbers in this assay, from the lowest: compounds 2, 1 and 3 (each within the scatter of the next).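

In this assay, cyclopentyl in place of phenyl on a saturated chain carbon bound to an amine nitrogen in a ring gives a number 10 percentage points higher from compound 2 to compound 3 (within the scatter). For this pair, then, a six-membered aromatic ring of carbon only can be exchanged for a five-membered non-aromatic ring of carbon only without a difference this read-out can resolve, so an aromatic ring at this place is not needed for a high number. Nothing measured here explains why the two rings read alike.

Still open, on these data alone, is whether a carboxylic acid or an open butyl chain at this place would also keep the number high. Also open, as far as these compounds go, is whether phenyl and cyclopentyl could be told apart by a full potency measurement rather than a reading at one concentration.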